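Notes on a fluoroindole myeloperoxidase series: compound 2 to compound 4

The source may report more compounds than this note shows. Statements on the series, on what has been measured and on what is new or still open speak of the compounds shown alone.

Compound 2 `NCC(N)CCc1c[nH]c2ccc(F)cc12` gives 26 nM in an assay on isolated protein for inhibition of Myeloperoxidase (Homo sapiens), read by ELISA, with a stated time of 5 min (on this read-out lower numbers stand for stronger inhibition and higher numbers for weaker inhibition), and is the only entry with a single number. Compound 3 `NCCSCCCc1c[nH]c2c(F)cccc12` is reported only at an assay limit, > 100 nM, not as a number. Compound 1 `N#CCCCc1c[nH]c2ccc(C(=O)O)cc12` is recorded in this assay as "not active" (no number reported). Within the data shown here, one of the three results is thus a limit (the limit of > 100 nM in this assay, at which 1 of the 3 values shown sits), which leaves no step between measured compounds to calibrate from.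

Compound 4 `ONCCCc1c[nH]c2ccc(F)cc12` has not yet been run in this assay. Relative to compound 2 the change is (hydroxyamino)methyl in place of 1,2-diaminoethyl on a saturated chain carbon, two bonds along the chain from an aromatic carbon. Among the measured compounds shown here, with no measured step to lean on, a modest weakening beyond the scatter is expected, a 3.1-fold higher number from compound 2 to compound 4 (0.49 log units; beyond the scatter). Compound 4 is estimated at 80 nM, with a range from 25 nM to 300 nM.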

Compound 4, half-maximal inhibitory concentration: 21 nM
Estimate against measurement, compound 4: 3.8-fold (0.58 log units) above; measured number below the stated range.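

Among these compounds, replacing 1,2-diaminoethyl with (hydroxyamino)methyl on a saturated chain carbon, two bonds along the chain from an aromatic carbon, gives a 1.2-fold lower number from compound 2 to compound 4 (0.09 log units; within the scatter) in this assay and so provides the first readable step. At this place, the two side chains cannot be told apart on this read-out, despite their different atoms. Nothing on record bears on why this step stays so small.

As far as these compounds go, a plain amine or a longer chain ending in a hydroxyamino group remains open at this place. So does a carboxylic acid there on the core of compound 4.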